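The source may hold more compounds than are shown below. What is called first, only, known or untested is meant among the compounds shown, and "the series" means these compounds.

Measured so far in an assay on isolated protein for displacement of a labelled ligand from 5-hydroxytryptamine receptor 6 (Homo sapiens), read by radioligand binding; a higher number here means a weaker inhibitor, a lower number a stronger inhibitor:
Compound 1 `CC(C)c1cc2c(cc1NS(=O)(=O)c1ccc(-c3ccc(Cl)cc3)cc1)CCN(C)CC2` gives 12.6 nM.
Compound 2 `Cc1cc2c(cc1NS(=O)(=O)c1ccc(-c3ccc(Cl)cc3)cc1)CCN(C)CC2` gives 15.9 nM.
Compound 3 `COc1cc2c(cc1NS(=O)(=O)c1ccc(-c3ccc(Cl)cc3)cc1)CCN(C)CC2` gives 10 nM.

Compound 3 gives the lowest number of the three, but its gap to compound 1 and its gap to compound 2 both stay within the scatter, so the three compounds cannot be told apart on these numbers. Compound 4 `CN1CCc2cc(Br)c(NS(=O)(=O)c3ccc(-c4ccc(Cl)cc4)cc3)cc2CC1` differs from compound 3 by one change: bromo in place of methoxy on an aromatic carbon. Three measured steps swap a group at this same place: a 1.3-fold higher number from compound 1 to compound 2 (0.10 log units; within the scatter), a 1.3-fold lower number from compound 1 to compound 3 (0.10 log units; within the scatter) and a 1.6-fold lower number from compound 2 to compound 3 (0.20 log units; within the scatter), every one within the scatter. Bromo has not been tried at this place, yet isopropyl, methyl and methoxy all gave much the same number, so no step beyond the scatter is expected in this assay. The estimated step is a 1.3-fold higher number from compound 3 to compound 4 (0.11 log units; within the scatter). Compound 4 is expected to give about 13 nM, with a range from 5 nM to 35 nM.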

Compound 4, inhibition constant: 50.1 nM
For compound 4 the middle estimate is 3.9-fold (0.59 log units) below the measured one; the whole stated range lies below it.
By their numbers in this assay, from the lowest: compounds 3, 1 and 2 (each within the scatter of the next); then compound 4.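

In this assay this position does not treat every group alike: isopropyl, methyl and methoxy could not be told apart, but bromo stands clear of all three (a 5.0-fold higher number from compound 3 to compound 4 (0.70 log units; beyond the scatter); a 3.2-fold higher number from compound 2 to compound 4 (0.50 log units; beyond the scatter); a 4.0-fold higher number from compound 1 to compound 4 (0.60 log units; beyond the scatter)), each step beyond the scatter. So the flat picture from the earlier compounds does not extend to every group placed here. No measurement shown explains why bromo differs from the other three groups. Still open, on these data alone, is whether chloro, fluoro, an amine or a longer chain at this place would track bromo or the earlier three groups.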